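Two Methoxy Groups on a Lipoic Acid–Coumarin Hybrid

The source may hold more compounds than are shown below. What is called first, only, known or untested is meant among the compounds shown, and "the series" means these compounds.

Measured compounds:
compound 1 `O=C(CCCCC1CCSS1)NCc1cn(CCCCOc2ccc3cc(-c4ccccc4)c(=O)oc3c2)nn1`: 20.5%
compound 2 `COc1ccc(-c2cc3ccc(OCCCCn4cc(CNC(=O)CCCCC5CCSS5)nn4)cc3oc2=O)cc1`: 55.3%
compound 3 `COc1ccc(-c2cc3ccc(OCCCCCn4cc(CNC(=O)CCCCC5CCSS5)nn4)cc3oc2=O)cc1`: 52.8%

All three were tested in a functional assay on PC-12 cells (Rattus norvegicus) for cytotoxicity, read by MTT assay, with stated times of 3 h and 2 h, tested at 50 uM; on this read-out higher numbers stand for a stronger effect at the one concentration tested and lower numbers for a weaker effect. Compound 1 gives 20.5%, compound 2 gives 55.3% and compound 3 gives 52.8%.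

Compound 1 and compound 2 differ in one place: methoxy in place of hydrogen on an aromatic carbon. This change made a number 34.8 percentage points higher from compound 1 to compound 2 (beyond the scatter). The values of compound 2 and compound 3 lie within the usual scatter of each other, so nothing about their order can be said.

Compound 4 `COc1ccc(-c2cc3ccc(OCCCCCn4cc(CNC(=O)CCCCC5CCSS5)nn4)cc3oc2=O)cc1OC` has not yet been measured. It differs from compound 3 in one place: methoxy in place of hydrogen on an aromatic carbon. Among the measured compounds shown here, this is the same kind of change as the one from compound 1 to compound 2, but not the same: in the earlier change the entering group sits para to a large group, whereas in the new one it sits ortho to a methoxy group and meta to a large group. The difference between the core of compound 1 and the core of compound 3 is not broken down here.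

Because the earlier change gave a number 34.8 percentage points higher from compound 1 to compound 2 (beyond the scatter), a methoxy at this part of the molecule has already once raised the read-out strongly. A second methoxy at a different spot on the same ring is expected to give a smaller step, a number 3.2 percentage points higher from compound 3 to compound 4 (within the scatter), since compound 3 already carries the first methoxy and its value 52.8% sits in the higher part of the set. For compound 4 the expected value in this assay is 56%, with a likely range from 38% to 74%.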

Compound 4, a percentage reported as activity, at one concentration (the size of the read-out at that concentration, not a potency): 55%
Beside the measured number, compound 4's estimate is 1 percentage points above it, within the range that was stated.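

In this assay, going from 4-methoxyphenyl to 3,4-dimethoxyphenyl gave a number 2.2 percentage points higher from compound 3 to compound 4 (within the scatter), so compound 3 and compound 4 cannot be put in order on this read-out. A methoxy in place of a hydrogen on an aromatic carbon therefore did not bring the same step on both cores, and the earlier large step cannot simply be carried over to another member of this series: the same change on two cores in this assay, a number 34.8 percentage points higher (beyond the scatter) from compound 1 to compound 2 and a number 2.2 percentage points higher (within the scatter) from compound 3 to compound 4, 32.6 percentage points apart, beyond the scatter of two such steps. This does not show what sets the two steps apart, as they differ in more than the core: only in compound 4 does the entering methoxy sit ortho to a methoxy group and meta to a large group, and two steps cannot separate the effect of its place from that of the rest of the molecule.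

The compounds shown leave open whether a second methoxy on the core of compound 1 would give a step like the one to compound 4, and how a hydroxyl group or a chlorine atom at the same place on the ring would compare with methoxy. They also leave open how a longer chain between the coumarin oxygen and the triazole would behave when paired with the 3,4-dimethoxyphenyl group.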